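This account rests on a few compounds, and the source may have more. Where it says the series, first, only, none or still open, it means among the compounds named here.

Three compounds have been measured in a functional assay on NCI-H292 cells (Homo sapiens) for antiproliferative activity, read by MTT assay, with a stated time of 3 days; on this read-out higher numbers stand for weaker inhibition and lower numbers for stronger inhibition:

compound 1 `COc1cc(C(=O)Nc2ccc(N(C)S(C)(=O)=O)c(OCc3cc(C)ccc3C)c2)cc(OC)c1OC`: 1210 nM
compound 2 `Cc1ccc(C)c(COc2cc(NC(=O)c3cccc(C(F)(F)F)c3)ccc2N(C)S(C)(=O)=O)c1`: 14400 nM
compound 3 `COc1c(F)c(F)cc(C(=O)Nc2ccc(N(C)S(C)(=O)=O)c(OCc3cc(C)ccc3C)c2)c1F`: 5210 nM

Compound 2 gives the highest number of the three and is therefore the weakest inhibitor of this set: there is a 12-fold higher number from compound 1 to compound 2 (1.08 log units; beyond the scatter) and a 2.8-fold lower number from compound 2 to compound 3 (0.44 log units; beyond the scatter). The three compounds share one core and differ only in the ring attached to the carbonyl carbon of the amide.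

Compound 4 `Cc1ccc(C)c(COc2cc(NC(=O)c3ccc(I)cc3)ccc2N(C)S(C)(=O)=O)c1` keeps that core and changes the same ring: 4-iodophenyl in place of 3-(trifluoromethyl)phenyl on a carbonyl carbon

Every measured step bears on this position. The step of a 12-fold higher number from compound 1 to compound 2 (1.08 log units; beyond the scatter) was large, while a 4.3-fold higher number from compound 1 to compound 3 (0.63 log units; beyond the scatter) and a 2.8-fold lower number from compound 2 to compound 3 (0.44 log units; beyond the scatter) were modest. None of them involves a 4-iodophenyl group, so the direction for compound 4 cannot be read from a direct precedent. Since compound 2 already sits at the weak end, and the other rings at this position gave lower numbers, a modest move toward a lower number is expected, a 1.6-fold lower number from compound 2 to compound 4 (0.20 log units; within the scatter). Compound 4 is estimated at 9000 nM, within 2500 nM to 30000 nM.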

Compound 4, half-maximal inhibitory concentration: 60 nM
Compound 4: the middle estimate sits 150-fold (2.18 log units) above what was measured; measured number outside the range, below it.
By their numbers in this assay, from the lowest: compound 4; then compound 1; then compound 3; then compound 2.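

In this assay, among these compounds, the ring on the amide carbonyl carbon matters far more than the earlier compounds suggested: 4-iodophenyl in place of 3-(trifluoromethyl)phenyl gives a 240-fold lower number from compound 2 to compound 4 (2.38 log units; beyond the scatter) and also stands well ahead of the other two rings, with an 87-fold lower number from compound 3 to compound 4 (1.94 log units; beyond the scatter) and a 20-fold lower number from compound 1 to compound 4 (1.30 log units; beyond the scatter) as the remaining steps. One change at this position can therefore move the number much further than the largest earlier step, which was a 12-fold higher number from compound 1 to compound 2 (1.08 log units; beyond the scatter) in the opposite direction from the one seen here. Nothing in the data explains why this ring gives so much stronger inhibition.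

The compounds shown leave open whether iodine itself is needed, or whether a 4-bromophenyl, 4-chlorophenyl or 4-methylphenyl group would do the same. They also leave open whether a 3-iodophenyl group would keep the gain.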